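The source may report more compounds than this note shows. Statements on the series, on what has been measured and on what is new or still open speak of the compounds shown alone.

Measured so far:
Compound 1, `CCn1cc(-c2nc3ccc(Cl)cc3[nH]2)c(=O)c2cc(F)c(N3CCNCC3)cc21`, gives 1800 nM in a functional assay on HepG2 cells (Homo sapiens) for cytotoxicity, read by sulforhodamine B assay, with a stated time of 48 h; a higher number here means a weaker inhibitor of growth, a lower number a stronger inhibitor of growth.
Compound 2, `CCn1cc(-c2nc3ccc(N)cc3[nH]2)c(=O)c2cc(F)c(N3CCNCC3)cc21`, gives only a limit of this assay, namely > 10000 nM.

Compound 2 thus stands at the edge of what this assay can report: its growth inhibition is too weak for a number, and the limit of > 10000 nM in this assay, at which 1 of the 2 values shown sits, is all that is known of it. Among the compounds with values here, the only measured step, an at least 5.5-fold higher number from compound 1 to compound 2 (0.74 log units; beyond the scatter), concerns amino in place of chloro and is what carried compound 2 to that limit.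

Compound 3, `CCn1cc(-c2nc3ccc(N)cc3[nH]2)c(=O)c2cc(F)c(N3CCN(C)CC3)cc21`, differs from compound 2 by methyl in place of hydrogen on an amine nitrogen in a ring. Within the data shown here, no measured step concerns a change of this kind, so there is no basis in these data for expecting a shift beyond the scatter in either direction in this assay. Compound 3 is therefore estimated to sit near 15000 nM, in the range 7000 nM to 40000 nM. This estimate amounts to a step that the limit leaves unreadable from compound 2 to compound 3, and most likely compound 3 is expected to return only a limit again.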

Compound 3, concentration for 50% growth inhibition: > 10000 nM
Compound 3: a limit, no number; the forecaster's own chance of this, stated with the estimate: 70%; the middle value is on the limit's open side.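

Compound 2 and compound 3 both return only a limit, not a number, so no step between them can be read: the limit of > 10000 nM in this assay, at which 2 of the 3 values shown sit.

Left open is whether 4-methylpiperazin-1-yl in place of piperazin-1-yl changes growth inhibition at all, and how weak compound 2 and compound 3 really are.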